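Side-chain exchange from compound 2 to compound 3

The source may report more compounds than this note shows. Statements on the series, on what has been measured and on what is new or still open speak of the compounds shown alone.

Values in an ADME assay on cells (Erythrocyte, Homo sapiens), read by spectrophotometry and hemolysis, with a stated time of 24 h; a lower number here means a stronger inhibitor, a higher number a weaker inhibitor:
- compound 1 `N=C(N)N/N=C/c1ccc(OCc2ccc3no[n+]([O-])c3c2)cc1`: > 200 uM (a limit)
- compound 2 `NC(=S)N/N=C/c1ccc(OCc2ccc3no[n+]([O-])c3c2)cc1`: > 200 uM (a limit)

Compound 2 has no number, only the limit > 200 uM. Compound 3 `NC(=O)N/N=C/c1ccc(OCc2ccc3no[n+]([O-])c3c2)cc1` differs from it by a group of 3 heavy atoms (1 carbon, 1 nitrogen, 1 oxygen; no ring) in place of a group of 3 heavy atoms (1 carbon, 1 nitrogen, 1 sulfur; no ring), on an amine nitrogen. Among the compounds with values here, the series so far rests on (the limit of > 200 uM in this assay, at which 2 of the 2 values shown sit). Within the data shown here, the one measured step bearing on this change is a step that the two limits leave unreadable from compound 1 to compound 2, so it gives no size to carry over. No step beyond the scatter is expected in this assay, in either direction. Compound 3 is estimated at 250 uM, with an expected range of 120 uM to 500 uM. The estimated change is a step that the limit leaves unreadable from compound 2 to compound 3.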

Compound 3, concentration for 50% inhibition: > 200 uM
Compound 3 gave a limit, no number; the forecaster's own chance of this, stated with the estimate: 85%; the middle value is on the limit's open side.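

In this assay, within the data shown here, compound 3 gives only a limit, > 200 uM, so no step among compound 1, compound 2 and compound 3 can be read. Whether these side chains differ at all stays open, as the series rests on one limit: the limit of > 200 uM in this assay, at which 3 of the 3 values shown sit.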